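The compounds below may be only part of what the source reports. "The series", "measured", "known", "first", "only" and "open" are said of these compounds alone.

Measured so far: compound 1, `COc1ccccc1C1CCN(c2ccn(CC3CC3)c(=O)c2C#N)CC1`, 265%; compound 2, `COc1ccc(C2CCN(c3ccn(CC4CC4)c(=O)c3C#N)CC2)cc1`, 257%.

In a functional assay on CHO cells for positive allosteric modulation of metabotropic glutamate receptor 2 (Homo sapiens), with a stated time of 30 min (on this read-out higher numbers stand for larger maximal responses and lower numbers for smaller maximal responses), compound 2 gives 257% and compound 1 gives 265%; the two are within the scatter of each other, the gap being a number 8 percentage points lower from compound 1 to compound 2 (within the scatter). Compound 3, `N#Cc1c(N2CCC(c3ccc(F)cc3F)CC2)ccn(CC2CC2)c1=O`, differs from compound 2 by 2,4-difluorophenyl in place of 4-methoxyphenyl on a saturated ring carbon. Among the measured compounds shown here, the one measured step at this same saturated ring carbon was a number 8 percentage points lower from compound 1 to compound 2 (within the scatter), so no step beyond the scatter is expected in this assay. Compound 3 is estimated at 250%, in the range 200% to 300%, an expected step of a number 7 percentage points lower from compound 2 to compound 3 (within the scatter).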

Compound 3, largest response reached (Emax), in percent of the reference or control that the assay uses: 272%
Estimate against measurement, compound 3: 22 percentage points below; the range from low to high includes it.
By their numbers in this assay, from the lowest: compounds 2, 1 and 3 (each within the scatter of the next, the first and the last beyond it).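

In this assay, among the compounds shown here, 2,4-difluorophenyl in place of 4-methoxyphenyl on the saturated ring carbon gives the first step at this position beyond the scatter: a number 15 percentage points higher from compound 2 to compound 3 (beyond the scatter). Against 2-methoxyphenyl the same group gives a number 7 percentage points higher from compound 1 to compound 3 (within the scatter), so the methoxy-free, difluorinated aryl group keeps the maximal response of both methoxyphenyl compounds at this carbon. Nothing available explains the step.

Open, going by these compounds, is how 4-fluorophenyl or 2-fluorophenyl alone would compare with 2,4-difluorophenyl. Also open, on these data alone, is whether an amine or a carboxylic acid on the phenyl ring would be tolerated at this carbon.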